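The compounds below may be only part of what the source reports. "The series", "measured", "known", "first", "only" and "open" are said of these compounds alone.

Working notes on the series. Compound 3 `Cc1ccccc1Nc1nc(Nc2ccc(N3CCN(C)CC3)cn2)ncc1Cl` carries the shared core of compound 1 `Cc1ccccc1Nc1nc(Nc2ccccn2)ncc1Cl` with 4-methylpiperazin-1-yl in place of hydrogen on an aromatic carbon. In an ADME assay on L02 cells (Homo sapiens) for inhibition, read by CCK-8 assay, with a stated time of 48 h (on this read-out lower numbers stand for stronger inhibition of growth and higher numbers for weaker inhibition of growth), compound 1 gives 6150 nM, and compound 3 gives 5980 nM; the step of a 1.0-fold lower number from compound 1 to compound 3 (0.01 log units; within the scatter) is within the scatter, so the two values stand together at the low end of the numbers shown, with nothing to separate them. Compound 2 `Cc1ccccc1Nc1nc(NCc2ccncc2)ncc1Cl` is the third member. In this assay compound 2 reports only a limit, > 100000 nM, as recorded in the limit of > 100000 nM in this assay, at which 1 of the 3 values shown sits. The step of an at least 16-fold higher number from compound 1 to compound 2 (1.21 log units; beyond the scatter) is thus a large one, but it concerns the other amine of the core, not the methylphenyl side.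

Compound 4 `Cc1cccc(Nc2nc(Nc3ccc(N4CCN(C)CC4)cn3)ncc2Cl)c1` is not yet measured. It differs from compound 3 by 3-methylphenyl in place of 2-methylphenyl on a nitrogen on an aromatic ring. Among the compounds with values here, no measured step touches the methylphenyl group, so neither an at least 16-fold higher number from compound 1 to compound 2 (1.21 log units; beyond the scatter) nor a 1.0-fold lower number from compound 1 to compound 3 (0.01 log units; within the scatter) bears directly on this change; the only guidance is that a small change elsewhere on the core left the value unchanged within the scatter. The expectation is therefore a step of a 1.1-fold higher number from compound 3 to compound 4 (0.04 log units; within the scatter) of no size beyond the scatter. Compound 4 is estimated at 6500 nM in this assay, with a range from 2000 nM to 25000 nM.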

Compound 4, concentration for 50% growth inhibition: 6080 nM
For compound 4 the middle estimate is 1.1-fold (0.03 log units) above the measured one, and the stated range covers the measured number.
By their numbers in this assay, from the lowest: compounds 3, 4 and 1 (each within the scatter of the next). At a limit, above all of these: compound 2.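

Moving the methyl group, with 3-methylphenyl in place of 2-methylphenyl on a nitrogen on an aromatic ring, gives the first measured step on this side of the shared core: in this assay it is a 1.0-fold higher number from compound 3 to compound 4 (0.01 log units; within the scatter). The two groups have the same heavy atoms, so this pair tests the placement of the methyl alone, and with 4-methylpiperazin-1-yl present that placement does not separate the two compounds, whereas the other amine of the core carries the one large step shown, an at least 16-fold higher number from compound 1 to compound 2 (1.21 log units; beyond the scatter). Nothing at hand bears on why this change leaves the two values together.

The compounds shown leave open whether the same holds without 4-methylpiperazin-1-yl, since the change is read on that one background only. Within the data shown here, they also leave open what a plain phenyl, or a methoxy, trifluoromethyl or carboxylic acid group in place of the methyl, would give on this side of the core, where only the two methylphenyl groups have values so far.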